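Compound 3 and the step to a fluoropyridine

This account rests on a few compounds, and the source may have more. Where it says the series, first, only, none or still open, it means among the compounds named here.

Compound 1 `O=C(Nc1cccc(F)c1)c1cc(=O)[nH]c2cc(F)ccc12`: > 20000 nM, a limit of the assay
Compound 2 `O=C(Nc1cccc(F)c1)c1cc(=O)[nH]c2cc(-c3cccc(F)c3)ccc12`: 12000 nM
Compound 3 `O=C(Nc1cccc(F)c1)c1cc(=O)[nH]c2cc(C3=CCOCC3)ccc12`: 10500 nM

In a functional assay on KYSE-70 cells for antiproliferative activity against KYSE-70 cell line (Homo sapiens), read by MTT assay, with a stated time of 72 h (on this read-out higher numbers stand for weaker inhibition and lower numbers for stronger inhibition), compound 3 gives 10500 nM. Its nearest neighbour is compound 2 at 12000 nM, and the two cannot be told apart: a 1.1-fold lower number from compound 2 to compound 3 (0.06 log units; within the scatter). Compound 1 gives only a limit, > 20000 nM. The two steps away from that limit, an at least 1.6-fold lower number from compound 1 to compound 2 (0.22 log units; that floor lies within the scatter) and an at least 1.9-fold lower number from compound 1 to compound 3 (0.27 log units; that floor lies within the scatter), therefore give floors and not true sizes.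

Compound 4 `O=C(Nc1cccc(F)c1)c1cc(=O)[nH]c2cc(-c3cccnc3F)ccc12` is the next to be measured. The change is a group of 7 heavy atoms (5 carbon, 1 nitrogen, 1 fluorine; one six-membered aromatic ring with 1 hetero atom) in place of a group of 6 heavy atoms (5 carbon, 1 oxygen; one six-membered non-aromatic ring with 1 hetero atom), on an aromatic carbon, so 2-fluoropyridin-3-yl takes over the site on the shared core. The closest guide is the exchange of a six-membered aromatic ring for a non-aromatic one, a 1.1-fold lower number from compound 2 to compound 3 (0.06 log units; within the scatter), which here would run in reverse. On that evidence, no shift beyond the scatter is expected in this assay. The expected step is a 1.0-fold higher number from compound 3 to compound 4 (0.02 log units; within the scatter). For compound 4 the estimated value is 11000 nM, with an expected range of 5000 nM to 20000 nM.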

Compound 4, half-maximal inhibitory concentration: > 20000 nM
Compound 4: a limit, no number; the forecaster's own chance of this, stated with the estimate: 20%; at least 1.8-fold (0.25 log units) between middle value and limit.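

Compound 4 gives > 20000 nM in this assay, which is a limit and not a number, so the change to 2-fluoropyridin-3-yl can only be sized by floors: an at least 1.9-fold higher number from compound 3 to compound 4 (0.27 log units; that floor lies within the scatter) and an at least 1.6-fold higher number from compound 2 to compound 4 (0.22 log units; that floor lies within the scatter). For the compounds shown here, both floors lie within the scatter, so the true size of each step stays unknown, but this is the first ring at this site that gives no number, unlike the rings of compound 2 and compound 3. The step between compound 1 and compound 4 cannot be read, and the limit of the assay now governs this small set: the limit of > 20000 nM in this assay, at which 2 of the 4 values shown sit.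

Left open is which part of 2-fluoropyridin-3-yl matters, the ring nitrogen or the fluorine, and a plain pyridin-3-yl would separate the two. Also open, going by these compounds, is how an amine or a carboxylic acid would read at this site.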